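The compounds below may be only part of what the source reports. "The series", "measured", "known", "first", "only" and "open" are said of these compounds alone.

Measured so far:
compound 1 `CCOC(=O)c1oc2ccc(N(Cc3ccccc3)S(=O)(=O)c3cccc(Cl)c3)cc2c1C`, which in a functional assay on HCT-116 cells (Homo sapiens) for inhibition, read by MTT assay, with a stated time of 72 h (on this read-out higher numbers stand for weaker inhibition and lower numbers for stronger inhibition), gives > 40000 nM, a limit of the assay and not a number
compound 2 `CCOC(=O)c1oc2ccc(N(Cc3ccccc3)S(=O)(=O)c3ccccc3)cc2c1C`, which in this assay gives > 40000 nM, again a limit of the assay
compound 3 `Cc1c(C(=O)O)oc2ccc(N(Cc3ccccc3)S(=O)(=O)c3ccc(Cl)cc3)cc12`, which in this assay gives 9130 nM

Compound 1 and compound 2 both sit at a limit, so the step that the two limits leave unreadable from compound 2 to compound 1 cannot be read; what is known of that pair is the limit of > 40000 nM in this assay, at which 2 of the 3 values shown sit. For the measured compounds named here, compound 3 carries the only number in the set, and the difference between its core and that of compound 2 is not broken down here.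

Compound 4 `Cc1c(C(=O)O)oc2ccc(N(Cc3ccc(Cl)cc3)S(=O)(=O)c3ccc(Cl)cc3)cc12` has not yet been measured. It differs from compound 3 by chloro in place of hydrogen on an aromatic carbon. The change from compound 2 to compound 1, (chloro in place of hydrogen on an aromatic carbon), is the same kind of change, though there the place is meta to a large group and here it is para to a large group. Since that earlier step is unreadable, the expectation rests on compound 3 alone and its 9130 nM. The step expected in this assay is a 1.3-fold lower number from compound 3 to compound 4 (0.12 log units; within the scatter), a shift expected to lie within the usual scatter. Compound 4 is estimated at 7000 nM, with a likely range from 2500 nM to 20000 nM.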

Compound 4, half-maximal inhibitory concentration: 3670 nM
The estimate for compound 4 lay 1.9-fold (0.28 log units) above the measured number; measured number inside the range.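

In this assay, replacing benzyl with 4-chlorobenzyl on the core that carries the carboxylic acid gives a 2.5-fold lower number from compound 3 to compound 4 (0.40 log units; beyond the scatter). This shows that the change can lower the number on that core, but it is a single step at a single place, para to a large group, and so does not by itself show a trend. Whether the change carries over from one core to another is not shown, since the only other chloro step, on the core of compound 2 and at a different place, cannot be read and its two compounds are known only through a limit of the assay, not a number: the limit of > 40000 nM in this assay, at which 2 of the 4 values shown sit.

The compounds shown leave open whether 4-chlorobenzyl would give any readable step on the core of compound 2, where the ethyl ester stands in place of the carboxylic acid. They also leave open whether fluoro, methoxy or trifluoromethyl in place of the chloro would give a step of similar size.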